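The source may hold more compounds than are shown below. What is called first, only, known or untested is meant among the compounds shown, and "the series" means these compounds.

In an ADME assay for permeability, using PAMPA, at pH 7.4 (on this read-out lower numbers stand for lower permeability and higher numbers for higher permeability), compound 1 `Cc1ccc(NC(=O)Nc2cc(C)nc3ccccc23)cc1` gives 669 10^-6 cm/s, compound 2 `Cc1cc(NC(=O)Nc2ccc(F)cc2)c2ccccc2n1` gives 801 10^-6 cm/s and compound 3 `Cc1cc(NC(=O)Nc2ccc(C(F)(F)F)cc2)c2ccccc2n1` gives 2 10^-6 cm/s. That puts compound 2 level with compound 1 and far above compound 3. The next structure, compound 4 `Cc1cc(NC(=O)Nc2cccnc2)c2ccccc2n1`, has pyridin-3-yl in place of 4-fluorophenyl on an amide-type nitrogen. The measured steps each swap a group on an aromatic carbon, and none replaces the whole ring, so they offer only indirect guidance. Fluoro in place of methyl gives a 1.2-fold higher number from compound 1 to compound 2 (0.08 log units; within the scatter), which stays within the scatter. Trifluoromethyl in place of fluoro gives a 400-fold lower number from compound 2 to compound 3 (2.60 log units; beyond the scatter), a large step showing that one small edit can pull this read-out down sharply. With only those two precedents, a moderate fall is expected rather than a collapse, and the estimated step is a 4.0-fold lower number from compound 2 to compound 4 (0.60 log units; beyond the scatter). The estimated value for compound 4 is 200 10^-6 cm/s, with an expected range from 20 10^-6 cm/s to 800 10^-6 cm/s.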

Compound 4, apparent permeability: 63 10^-6 cm/s
Beside the measured number, compound 4's estimate is 3.2-fold (0.50 log units) above it; the range from low to high includes it.
By their numbers in this assay, from the lowest: compound 3; then compound 4; then compounds 1 and 2 (each within the scatter of the next).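

The earlier steps shown here each swapped one group on an aromatic carbon, whereas here the whole ring on the amide-type nitrogen changes, from a ring of carbon only to one holding a hetero atom. In this assay pyridin-3-yl in place of 4-fluorophenyl gives a 13-fold lower number from compound 2 to compound 4 (1.10 log units; beyond the scatter) and pyridin-3-yl in place of 4-methylphenyl gives an 11-fold lower number from compound 1 to compound 4 (1.03 log units; beyond the scatter) as well, so two separate comparisons, both large, agree that this ring swap brings a clear drop on this read-out. Nothing available here explains that drop.

The swap also removes the fluoro or methyl group, so the effect of the ring nitrogen cannot be separated from the effect of losing that group; plain phenyl on the same nitrogen would separate them. On these data alone, whether a saturated ring such as cyclohexyl, or a phenyl ring carrying an amine or a carboxylic acid, would fall as far also stays open.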